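From pyrazin-2-yl to 4-chlorophenyl on the amide nitrogen

This account rests on a few compounds, and the source may have more. Where it says the series, first, only, none or still open, it means among the compounds named here.

In an ADME assay on J774 cells (Mus musculus) for cytotoxicity, read by resazurin assay, with a stated time of 24 h (on this read-out lower numbers stand for higher toxicity in this test and higher numbers for lower toxicity in this test), compound 2 `COC(=O)c1cc2nc(SCC(=O)Nc3cnccn3)[nH]c2cc1Cl` gives 135000 nM and compound 1 `COC(=O)c1cc2nc(SCC(=O)Nc3ccc(Cl)cn3)[nH]c2cc1Cl` gives 82700 nM, so the two lie within the usual scatter of each other. Compound 3 `COC(=O)c1cc2nc(SCC(=O)Nc3ccc(Cl)cc3)[nH]c2cc1Cl` carries 4-chlorophenyl in place of pyrazin-2-yl on an amide-type nitrogen. Among the compounds with values here, the one measured step bearing on this, a 1.6-fold higher number from compound 1 to compound 2 (0.21 log units; within the scatter), exchanged a chlorine-bearing ring for one without chlorine and stayed within the scatter. A similarly small step, pointing downward, is therefore expected, a 1.9-fold lower number from compound 2 to compound 3 (0.29 log units; within the scatter). Compound 3 is estimated at 70000 nM, with an expected range of 30000 nM to 140000 nM.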

Compound 3, half-maximal cytotoxic concentration: 90400 nM
Compound 3: the middle estimate sits 1.3-fold (0.11 log units) below what was measured; low and high end bracket the measured number.
By their numbers in this assay, from the lowest: compounds 1, 3 and 2 (each within the scatter of the next).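

In this assay, the ring on the amide-type nitrogen was changed to 4-chlorophenyl, giving a 1.5-fold lower number from compound 2 to compound 3 (0.17 log units; within the scatter) and a 1.1-fold higher number from compound 1 to compound 3 (0.04 log units; within the scatter). A ring of carbon only therefore sits within the scatter of both nitrogen-containing rings, so this read-out separates none of the three groups at this position. No measurement here explains why the values stay so close. Still open, going by these compounds, is whether a different kind of group on this nitrogen, such as a cyclohexyl ring or a chain ending in a carboxylic acid, would move the number beyond the scatter.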